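The source may hold more compounds than are shown below. What is called first, only, known or untested is meant among the compounds shown, and "the series" means these compounds.

Among the measured compounds shown here, in a physicochemical assay for lipophilicity, read by LC-MS, using the shake flask method (a higher number here means a more lipophilic compound, a lower number a more polar compound), compound 3 (`O=C1COc2ccc(CNC3CCN(CCN4C(=O)COc5ccc(OC(F)(F)F)cc54)CC3)nc2N1`) gives 1.8 and stands highest of the three compounds measured so far. Compound 1 (`O=C1COc2ccc(CNC3CCN(CCN4C(=O)COc5ccc(Br)cc54)CC3)nc2N1`) follows at 1.4 and compound 2 (`O=C1COc2ccc(CNC3CCN(CCN4C(=O)COc5ccc(NC(=O)C(F)(F)F)cc54)CC3)nc2N1`) lies lowest at 0.2 on the same scale. All three share one core and differ only in the group on a single aromatic carbon. Compound 4 (`O=C1COc2ccc(CNC3CCN(CCN4C(=O)COc5ccc(F)cc54)CC3)nc2N1`) keeps that core and carries fluoro in place of trifluoromethoxy on an aromatic carbon.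

The measured steps at this carbon give some guidance. Two of them involve ((trifluoromethyl)carbonyl)amino and are large, namely a number 1.20 log units lower from compound 1 to compound 2 (beyond the scatter) and a number 1.60 log units higher from compound 2 to compound 3 (beyond the scatter) in the opposite sense. They show that a swap here can shift the number a long way, but that group is no halogen, so they are a weak guide. For the measured compounds named here, the closest precedent is the modest a number 0.40 log units higher from compound 1 to compound 3 (beyond the scatter) for trifluoromethoxy in place of bromo. Fluoro, like the bromo of compound 1, is a halogen, so that step is expected to be undone at least, and the fall may go further. The expected change is a number 0.80 log units lower from compound 3 to compound 4 (beyond the scatter) and would lie beyond the scatter. The estimate for compound 4 is 1 with an expected range from 0.6 to 1.4 in this assay once it is measured.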

Compound 4, distribution coefficient: 0.9
Beside the measured number, compound 4's estimate is 0.10 log units above it; low and high end bracket the measured number.
By their numbers in this assay, from the lowest: compound 2; then compound 4; then compound 1; then compound 3.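

The new result shows that the two halogens are not interchangeable at this aromatic carbon: in this assay, fluoro in place of bromo gives a number 0.50 log units lower from compound 1 to compound 4 (beyond the scatter), so the halogen chosen matters and not only the fact of having a halogen there. Replacing trifluoromethoxy with fluoro gives a number 0.90 log units lower from compound 3 to compound 4 (beyond the scatter), which carries the number past the level of compound 1 and not merely back to it. Fluoro still does not reach the low end of the series, as its place in the ((trifluoromethyl)carbonyl)amino comparison gives a number 0.70 log units higher from compound 2 to compound 4 (beyond the scatter), and the four groups now stand apart in a clear order, with every step between them beyond the scatter.

Nothing in the data available here gives a reason for this order. As far as these compounds go, whether chloro would fall between fluoro and bromo, and where an amine or a carboxylic acid on the same carbon would land on this scale, remains open.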